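The source may report more compounds than this note shows. Statements on the series, on what has been measured and on what is new or still open speak of the compounds shown alone.

Compound 2 `CCCCCCCCS(=O)(=O)Nc1ccc(-c2ccc(Cl)cc2)cc1C(=O)O` and compound 1 `CCCCCCCCS(=O)(=O)Nc1cc(-c2cccc(F)c2)ccc1C(=O)O` share an octylsulfonamido-benzoic acid core and were both tested in an assay on mitochondria (strain BALB/c) for inhibition of glycerol-3-phosphate acyltransferase 1, mitochondrial (Mus musculus), read by scintillation counting, with a stated time of 10 min; on this read-out higher numbers stand for weaker inhibition and lower numbers for stronger inhibition. Compound 1 gives 32600 nM, while compound 2 gives 9200 nM, which is the lowest of the two numbers recorded; the gap between them is wide enough to lie beyond the usual scatter of repeated measurements, so compound 2 stands as the stronger inhibitor of this pair.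

The next compound, compound 3 `CCCCCCCCS(=O)(=O)Nc1ccc(C(=O)c2ccccc2OC)cc1C(=O)O`, differs from compound 2 in a single place: (2-methoxyphenyl)carbonyl in place of 4-chlorophenyl on an aromatic carbon. The leaving group is a halogenated aromatic ring; the entering group is larger, brings a carbonyl between the two rings, and carries two hydrogen-bond acceptors where the leaving group had none.

Going by the values given here, no pair of measured compounds that differ in only one place is available, so there is no direct precedent for this exchange. The step from compound 2 to compound 3 is therefore expected to be modest, a 1.3-fold higher number from compound 2 to compound 3 (0.12 log units; within the scatter), with the direction uncertain and a slight lean toward weaker inhibition. For compound 3 the estimated value in this assay is 12000 nM, expected to fall between 3000 nM and 50000 nM.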

Compound 3, half-maximal inhibitory concentration: 59200 nM
Estimate against measurement, compound 3: 4.9-fold (0.69 log units) below; measured number above the stated range.
By their numbers in this assay, from the lowest: compound 2; then compounds 1 and 3 (each within the scatter of the next).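

In this assay the exchange of 4-chlorophenyl for (2-methoxyphenyl)carbonyl on this aromatic carbon, meta to a carboxy group and para to a large group, gives a 6.4-fold higher number from compound 2 to compound 3 (0.81 log units; beyond the scatter) and so weakens inhibition. Going by these compounds alone, this is the first comparison between compounds that differ in one place, and it shows that the number responds to what stands on this carbon, with the 4-chlorophenyl of compound 2 the better of the two groups. The exchange alters several things at once, however, bringing in a carbonyl and a methoxy group and removing the chlorine, and the compounds shown give no measurement that explains the rise.

Within the data shown here, the single step cannot separate these contributions, so it remains open whether the carbonyl, the methoxy group or the loss of the chlorine carries most of the change. A (4-chlorophenyl)carbonyl group on this carbon would bear on that question, as would a plain phenyl or a 2-methoxyphenyl group joined directly to the ring, while a small group such as an amine would show whether an aromatic ring is needed here at all.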